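Carbonyl aryl exchange: from compound 2 to compound 3

A few compounds are considered here, and "the series" means these few. Any claim that something is new, unique, unknown or untested is made for them only; others in the source may bear on it.

Measured compounds:
compound 1 `COc1ccc(C(=O)/C=C/c2cc(-c3cc(OC)c(OC)c(OC)c3)n[nH]2)cc1OC`, a functional assay on ACHN cells (Homo sapiens) for inhibition, read by sulforhodamine B assay, with a stated time of 48 h; on this read-out higher numbers stand for weaker inhibition of growth and lower numbers for stronger inhibition of growth: 1660 nM
compound 2 `COc1ccc(C(=O)/C=C/c2cc(-c3cc(OC)c(OC)c(OC)c3)n[nH]2)cc1`, this assay: 1960 nM

Among the compounds with values here, compound 2 holds the highest of the two numbers so far, yet its only neighbour is compound 1, and the step of a 1.2-fold higher number from compound 1 to compound 2 (0.07 log units; within the scatter) does not separate the two beyond the scatter; the pair is best read as one level of growth inhibition. Within the data shown here, that step, hydrogen in place of methoxy on an aromatic carbon, is the single measured change.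

Compound 3 `COc1cc(-c2cc(/C=C/C(=O)c3ccc(F)c(F)c3)[nH]n2)cc(OC)c1OC` has not yet been measured. It differs from compound 2 by 3,4-difluorophenyl in place of 4-methoxyphenyl on a carbonyl carbon. Among the measured compounds shown here, no measured step concerns the group on the carbonyl carbon, so the step of a 1.2-fold higher number from compound 1 to compound 2 (0.07 log units; within the scatter) bears on it only in a general way: the one change tried on the shared core left the number within the scatter, and there is no evidence that a change at the other end behaves differently. On that basis a step of a 1.0-fold higher number from compound 2 to compound 3 (0.01 log units; within the scatter) is expected, that is, none beyond the scatter, with a wide range allowed for an untested position. Compound 3 is estimated at 2000 nM, between 600 nM and 7000 nM in this assay.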

Compound 3, concentration for 50% growth inhibition: 3260 nM
Compound 3: middle estimate off by 1.6-fold (0.21 log units), on the low side; measured number inside the range.
By their numbers in this assay, from the lowest: compounds 1, 2 and 3 (each within the scatter of the next).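

In this assay, the exchange on the carbonyl carbon gives a 1.7-fold higher number from compound 2 to compound 3 (0.22 log units; within the scatter), and the exchange starting from the 3,4-dimethoxyphenyl group gives a 2.0-fold higher number from compound 1 to compound 3 (0.29 log units; within the scatter). Within the data shown here, these are the first measured steps for the group on the carbonyl carbon, and they show that, across these three compounds, 3,4-difluorophenyl can stand in place of either methoxy-bearing phenyl group without a step beyond the scatter, so compounds 1, 2 and 3 are best read as one level of growth inhibition. Nothing available accounts for the size of these steps or ties them to any property of the groups exchanged.

The compounds shown leave open whether this flat response holds only among substituted phenyl groups, or whether a phenyl group carrying an amine or a carboxylic acid, a pyridine ring, or a longer chain on the carbonyl carbon would produce a step beyond the scatter. They also leave open whether the unchanged trimethoxy-substituted phenyl group on the shared core tolerates exchange in the same way, for instance for a phenyl group carrying a single methoxy or a hydroxyl.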